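Methoxy in Place of Hydrogen on Two Related Cores

This account rests on a few compounds, and the source may have more. Where it says the series, first, only, none or still open, it means among the compounds named here.

Measured in a functional assay on U-87MG ATCC cells for antiproliferative activity against U-87 MG (Homo sapiens), read by MTT assay, with a stated time of 48 h; on this read-out lower numbers stand for stronger inhibition and higher numbers for weaker inhibition:
compound 1 `Cc1nc(-c2ccc(Cl)cc2)sc1C(=O)CSc1nc(-c2ccccc2)c(C#N)c(=O)[nH]1` gives 27600 nM
compound 2 `COc1ccc(-c2nc(C)c(C(=O)CSc3nc(N)c(C#N)c(-c4ccccc4)n3)s2)cc1` gives 8540 nM
compound 3 `COc1ccc(-c2nc(SCC(=O)c3sc(-c4ccc(Cl)cc4)nc3C)[nH]c(=O)c2C#N)cc1` gives 35500 nM

Compound 1 and compound 3 share a core and differ by methoxy in place of hydrogen on an aromatic carbon; this change made a 1.3-fold higher number from compound 1 to compound 3 (0.11 log units; within the scatter). Compound 2 rests on a different core, and the difference between the two cores is not broken down here; its number is the lowest of the three, and its steps to compound 1 and compound 3 are both beyond the scatter. Compound 4 `COc1ccc(-c2nc(C)c(C(=O)CSc3nc(N)c(C#N)c(-c4ccc(OC)cc4)n3)s2)cc1` carries the same change relative to compound 2, namely (methoxy in place of hydrogen on an aromatic carbon). Because the same change gave a 1.3-fold higher number from compound 1 to compound 3 (0.11 log units; within the scatter), the step from compound 2 to compound 4 is expected to be small, about a 1.2-fold higher number from compound 2 to compound 4 (0.07 log units; within the scatter). For compound 4 the expected value is 10000 nM, within 4500 nM to 22000 nM.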

Compound 4, half-maximal inhibitory concentration: 1560 nM
Beside the measured number, compound 4's estimate is 6.4-fold (0.81 log units) above it; the whole stated range lies above it.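

On the core of compound 2, the change from phenyl to 4-methoxyphenyl gave a 5.5-fold lower number from compound 2 to compound 4 (0.74 log units; beyond the scatter) in this assay, whereas on the core shared by compound 1 and compound 3 it gave a 1.3-fold higher number from compound 1 to compound 3 (0.11 log units; within the scatter), so its effect did not carry over from one core to the other: the same change on two cores in this assay, a 1.3-fold higher number (0.11 log units; within the scatter) from compound 1 to compound 3 and a 5.5-fold lower number (0.74 log units; beyond the scatter) from compound 2 to compound 4, 7.0-fold (0.85 log units) apart, beyond the scatter of two such steps

These two pairs show that a step measured on one core need not predict the step on the other. They do not show which part of the difference between the cores matters, or how the change would behave on a third core.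

As far as these compounds go, it remains open whether an ethoxy group or an amine at the same place would also differ between the two cores. The same question applies to methoxy on other aromatic carbons.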